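A few compounds are considered here, and "the series" means these few. Any claim that something is new, unique, unknown or untested is made for them only; others in the source may bear on it.

Working notes on the series. Compound 1 `NCCCC[C@H](NC(=O)CN(c1nc(Cl)nc2[nH]cnc12)C1CC1)C(=O)OCc1ccccc1` is the reference point. In a functional assay on the whole organism (Tail, strain ICR) with Mus musculus as the target, in the tail flick test, with a stated time of 120 min, at a dose of 25 umol/kg by the oral route (on this read-out lower numbers stand for a weaker effect and higher numbers for a stronger effect at the one dose given), compound 1 gives 16.8%, the highest of the three numbers in hand, though its gap to each of the other two lies within the scatter. Compound 3 `NCCCC[C@H](NC(=O)CN(c1nc(Cl)nc2[nH]cnc12)C1CC1)C(=O)O` gives 16.4%, and compound 2 `CC(C)C[C@H](NC(=O)CN(c1ncnc2c1ncn2C1CCCCO1)C1CC1)C(=O)OCc1ccccc1` gives 12.8%. Within the data shown here, the one single-point step measured so far, a number 0.4 percentage points lower from compound 1 to compound 3 (within the scatter), is flat.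

The next compound, compound 4 `O=C(CN(c1nc(Cl)nc2[nH]cnc12)C1CC1)N[C@@H](CO)C(=O)OCc1ccccc1`, differs from compound 1 by hydroxy in place of 3-aminopropyl on a saturated chain carbon, two bonds along the chain from an amide-type nitrogen and a carbonyl carbon. Among the measured compounds shown here, no measured step touches this position: the step from compound 1 to compound 3 sits on the oxygen next to the carbonyl group, far from the saturated chain carbon changed here, and compound 2 differs from compound 1 in more than one place, so its value can only be set beside that of compound 1 as two numbers within the scatter of each other. What the three measured values do show is a narrow band with no movement beyond the scatter anywhere in it. With nothing pointing up or down, the expected step of a number 2.8 percentage points lower from compound 1 to compound 4 (within the scatter) is set close to zero, the uncertainty wide. Compound 4 is therefore estimated at 14%, in the range 4% to 26%.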

Compound 4, a percentage reported as activity, at one dose (the size of the read-out at that dose, not a potency): 34.5%
Compound 4: the middle estimate sits 20.5 percentage points below what was measured, outside the stated range (above it).
By their numbers in this assay, from the lowest: compounds 2, 3 and 1 (each within the scatter of the next); then compound 4.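

Among these compounds, the saturated chain carbon two bonds along the chain from an amide-type nitrogen and a carbonyl carbon is the first position where a single change moves the read-out in this assay beyond the scatter: a number 17.7 percentage points higher from compound 1 to compound 4 (beyond the scatter), whereas the one earlier single-point step, a number 0.4 percentage points lower from compound 1 to compound 3 (within the scatter), stayed flat. Hydroxy and 3-aminopropyl carry the same counts of hydrogen-bond donors and acceptors and neither has a net charge, so the step goes with a change those counts do not register, while the heavy-atom count of the group falls and its amine is gone. No measurement on this series explains the rise in compound 4.

This single step changes the chain length, removes the amine and adds the hydroxy all at once, so the compounds shown do not separate these contributions. A methyl group or a longer hydroxyalkyl chain at this carbon would bear on that question, and the carboxylic acid of compound 4 would show whether hydrogen in place of benzyl stays as flat with hydroxy at this position as it does in the step from compound 1.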